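This account rests on a few compounds, and the source may have more. Where it says the series, first, only, none or still open, it means among the compounds named here.

Measured in a functional assay on DU-145 cells (Homo sapiens) for inhibition; a lower number here means a stronger inhibitor, a higher number a weaker inhibitor:
- compound 1 `Oc1ccccc1-c1cc(-c2ccc(F)cc2)cc(-c2ccccc2O)n1`: > 50000 nM (a limit)
- compound 2 `Oc1cccc(-c2cc(-c3ccc(F)cc3)cc(-c3ccccc3O)n2)c1`: > 50000 nM (a limit)
- compound 3 `Oc1cccc(-c2cc(-c3ccc(F)cc3)cc(-c3cccc(O)c3)n2)c1`: 7120 nM

Compound 2 stands at the limit of > 50000 nM in this assay, at which 2 of the 3 values shown sit, so it has only a limit and no number.

Compound 4 `Oc1cccc(-c2cc(-c3ccc(C(F)(F)F)cc3)cc(-c3ccccc3O)n2)c1` differs from compound 2 in one group: trifluoromethyl in place of fluoro on an aromatic carbon. This is trifluoromethyl in place of fluoro on an aromatic carbon, para to a large group.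

Neither measured step touches this position. Both place 3-hydroxyphenyl where 2-hydroxyphenyl stood. Among the compounds with values here, the first is a step that the two limits leave unreadable from compound 1 to compound 2. Within the data shown here, the second is an at least 7.0-fold lower number from compound 2 to compound 3 (0.84 log units; beyond the scatter), and it is the only readable step. Compound 4 keeps the 2-hydroxyphenyl group whose replacement gave an at least 7.0-fold lower number from compound 2 to compound 3 (0.84 log units; beyond the scatter), so that gain is not expected to carry over. The exchange of fluoro for trifluoromethyl has not been measured in this series, and no step beyond the scatter is expected in this assay, with a further limit quite possible.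

The estimated step is an at least 1.2-fold lower number from compound 2 to compound 4 (0.09 log units; that floor lies within the scatter).

For compound 4 the expected value is 40000 nM, with an estimated range of 12000 nM to 90000 nM.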

Compound 4, half-maximal inhibitory concentration: > 50000 nM
Compound 4 was reported as a limit; the forecaster's own chance of this, stated with the estimate: 60%; middle value at least 1.2-fold (0.09 log units) away from the limit.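

In this assay compound 4 gives > 50000 nM, a limit and not a number. Compound 2 also stands at a limit, so no step can be read between compound 2 and compound 4. Going by these compounds, what trifluoromethyl in place of fluoro does to inhibition remains open.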